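A few compounds are considered here, and "the series" means these few. Any claim that something is new, unique, unknown or untested is made for them only; others in the source may bear on it.

Measured compounds:
- compound 1, `Cc1nc(-c2ccc(C(F)(F)F)cc2)sc1CNc1ccc(OCC(=O)O)cc1`: 288 nM
- compound 2, `O=C(O)[C@H]1C[C@@H]1c1ccc(NCc2cccc(Oc3ccccc3)c2)cc1`: 12.3 nM; 13.5 nM (2 entries)

Two compounds carry numbers in a functional assay on CHO cells for agonist activity at Free fatty acid receptor 1 (Homo sapiens); a higher number here means that more compound is needed for the effect, a lower number that less compound is needed. Compound 1 gives 288 nM, and compound 2 gives 12.3 nM; 13.5 nM (2 entries), the repeated entries of compound 2 agreeing closely with one another (the several entries of compound 2 in this assay, 12.3 nM; 13.5 nM (2 entries)). Of the two measured values, compound 1 stands at the higher one; a further entry for compound 1 in this assay reports no single number.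

Compound 3, `Cc1nc(-c2ccc(C(F)(F)F)cc2)sc1CNc1ccc([C@H]2C[C@@H]2C(N)=O)cc1`, has not yet been measured in this assay. It keeps the core of compound 1 and changes one group: 2-carbamoylcyclopropyl in place of carboxymethoxy on an aromatic carbon. Put simply, a 2-carbamoylcyclopropyl replaces a carboxymethoxy on an aromatic carbon, so the acid of compound 1 is gone and a primary amide on a three-membered ring takes its place. Within the data shown here, no measured pair of compounds follows this exact change, so the size of the step cannot be read from the data. The step from compound 1 to compound 3 is expected to be a 5.2-fold higher number from compound 1 to compound 3 (0.72 log units; beyond the scatter), in the direction of more compound being needed, beyond the scatter. Compound 3 is therefore estimated at 1500 nM, with a range from 300 nM to 8000 nM.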

Compound 3, half-maximal effective concentration: 4.47 nM
Beside the measured number, compound 3's estimate is 340-fold (2.53 log units) above it, and the stated range ends above it.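

In this assay, putting 2-carbamoylcyclopropyl in place of carboxymethoxy on an aromatic carbon, para to a large group, gives a 64-fold lower number from compound 1 to compound 3 (1.81 log units; beyond the scatter), a large step towards less compound being needed. The earlier compounds shown here both carry a carboxylic acid, so they could not show what this pair shows: on the core of compound 1, a low number does not depend on having a carboxylic acid at this place, and a primary amide on a three-membered ring of carbon serves there far better than carboxymethoxy. Nothing in the data shown accounts for the size of this step.

The step replaces the linking oxygen and chain, the ring and the end group all at once, so the compounds shown leave open how much of it belongs to the three-membered ring and how much to the primary amide. Also open, going by these compounds, is how this position would respond to a 2-carboxycyclopropyl, a nitrile or an N-methyl amide on the same ring, or to the opposite arrangement of the two stereocentres.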